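A few compounds are considered here, and "the series" means these few. Any claim that something is new, unique, unknown or untested is made for them only; others in the source may bear on it.

In a functional assay on PC-3 cells (Homo sapiens) for inhibition, with a stated time of 72 h (a lower number here means a stronger inhibitor, a higher number a weaker inhibitor), compound 1 `Cc1nc(-c2nc[nH]n2)ccc1-c1cnc2c(n1)N([C@H]1CC[C@@H](O)CC1)C(=O)CN2`, which carries 4-hydroxycyclohexyl on an amide-type nitrogen in a ring, gives 37 nM. Compound 2 `Cc1nc(-c2nc[nH]n2)ccc1-c1cnc2c(n1)N(CC1CCOCC1)C(=O)CN2`, with (oxan-4-yl)methyl in its place, gives 82 nM, the higher of the two numbers. Compound 3 `CO[C@H]1CC[C@@H](CN2C(=O)CNc3ncc(-c4ccc(-c5nc[nH]n5)nc4C)nc32)CC1` differs from compound 2 in one place: 4-methoxycyclohexyl in place of oxan-4-yl on a saturated chain carbon bound to an amide-type nitrogen in a ring. The same difference reads as (oxan-4-yl)methyl to (4-methoxycyclohexyl)methyl. Within the data shown here, only one measured step bears on this change, and only loosely: a 2.2-fold higher number from compound 1 to compound 2 (0.35 log units; beyond the scatter), a modest step that also exchanges the group on that nitrogen. Among the measured compounds shown here, no measured pair isolates the change made here. A modest shift at most is therefore expected, with the direction poorly defined and a slightly lower number favoured. The expected step, a 1.3-fold lower number from compound 2 to compound 3 (0.10 log units; within the scatter), is an estimate. For compound 3, the estimated value in this assay is 65 nM, with an expected range of 25 nM to 170 nM.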

Compound 3, half-maximal inhibitory concentration: 24 nM
Compound 3: middle estimate off by 2.7-fold (0.43 log units), on the high side, outside the stated range (below it).
By their numbers in this assay, from the lowest: compounds 3 and 1 (each within the scatter of the next); then compound 2.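

In this assay, among these compounds, the step of a 3.4-fold lower number from compound 2 to compound 3 (0.53 log units; beyond the scatter) lies beyond the scatter, the first pair to isolate 4-methoxycyclohexyl in place of oxan-4-yl on a saturated chain carbon bound to an amide-type nitrogen in a ring. The step of a 1.5-fold lower number from compound 1 to compound 3 (0.19 log units; within the scatter) lies within the scatter, so (4-methoxycyclohexyl)methyl and 4-hydroxycyclohexyl on that nitrogen cannot be told apart here, and compound 2 alone stands apart among the three. No available measurement accounts for the shift.

The compounds shown do not separate the methoxy group from the all-carbon ring, since both enter in the same change. As far as these compounds go, how a plain cyclohexylmethyl, (4-hydroxycyclohexyl)methyl or (4-aminocyclohexyl)methyl group would read at this position remains open.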